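Swapping the imidazole-bearing ring for a sulfonylpyrrolidine

The source may report more compounds than this note shows. Statements on the series, on what has been measured and on what is new or still open speak of the compounds shown alone.

Among the measured compounds shown here, compound 3 `Brc1nn(-c2ccc3ncccc3c2)c2nc(N[C@@H]3CC[C@@H](c4ncc[nH]4)C3)ncc12` is the only member of this small set with a definite number in an assay on isolated protein for inhibition of eIF-2-alpha kinase GCN2 (Homo sapiens); on this read-out higher numbers stand for weaker inhibition and lower numbers for stronger inhibition: compound 3 gives 21 nM. Its two companions carry open chains on the same nitrogen. In this assay compound 1 `COCCNC(=O)CNc1ncc2c(Br)nn(-c3ccc4ncccc4c3)c2n1` reaches only the limit > 1000 nM. Compound 2 `COCCNC(=O)CCNc1ncc2c(Br)nn(-c3ccc4ncccc4c3)c2n1` likewise sits at the limit > 1000 nM. The step that the two limits leave unreadable from compound 1 to compound 2 is therefore unreadable, while an at least 47-fold lower number from compound 1 to compound 3 (1.67 log units; beyond the scatter) and an at least 47-fold lower number from compound 2 to compound 3 (1.67 log units; beyond the scatter) show the ring-bearing group far ahead of either chain, a reading set by the limit of > 1000 nM in this assay, at which 2 of the 3 values shown sit.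

Compound 4 `CS(=O)(=O)N1CC[C@@H](Nc2ncc3c(Br)nn(-c4ccc5ncccc5c4)c3n2)C1` is the open question. a group of 9 heavy atoms (5 carbon, 1 nitrogen, 2 oxygen, 1 sulfur; one five-membered non-aromatic ring with 1 hetero atom) in place of a group of 10 heavy atoms (8 carbon, 2 nitrogen; one five-membered non-aromatic ring of carbon only, one five-membered aromatic ring with 2 hetero atoms), on a nitrogen on an aromatic ring The change keeps a ring on that nitrogen, unlike the chains of compounds 1 and 2, but drops the five-membered aromatic ring with 2 hetero atoms. For the measured compounds named here, no measured step isolates that loss on its own. The expected outcome for compound 4 is a moderate weakening, a 7.1-fold higher number from compound 3 to compound 4 (0.85 log units; beyond the scatter), giving an estimated 150 nM with a range from 40 nM to 600 nM.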

Compound 4, half-maximal inhibitory concentration: 90 nM
The estimate for compound 4 lay 1.7-fold (0.22 log units) above the measured number; measured number inside the range.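

In this assay, the five-membered aromatic ring with 2 hetero atoms can be lost without losing most of the advantage over the open chains: changing to 1-(methylsulfonyl)pyrrolidin-3-yl gives only a 4.3-fold higher number from compound 3 to compound 4 (0.63 log units; beyond the scatter). The new group also stands well clear of both chains, with an at least 11-fold lower number from compound 2 to compound 4 (1.04 log units; beyond the scatter) and an at least 11-fold lower number from compound 1 to compound 4 (1.04 log units; beyond the scatter). These last two steps are minimum sizes, read against a limit of the assay and not against a number: the limit of > 1000 nM in this assay, at which 2 of the 4 values shown sit.

The change alters the saturated ring, removes the aromatic ring and adds the methylsulfonyl group all at once, and the compounds shown do not tell which of these parts sets the step. A free pyrrolidin-3-yl amine, a 1-acetylpyrrolidin-3-yl group or a plain cyclopentyl group would help to separate those shares.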